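Compound 3 to compound 4: thiophen-3-yl replaces furan-2-yl

This account rests on a few compounds, and the source may have more. Where it says the series, first, only, none or still open, it means among the compounds named here.

In a functional assay on A549 cells (Homo sapiens), read by MTT assay, with a stated time of 72 h (on this read-out higher numbers stand for weaker inhibition and lower numbers for stronger inhibition), compound 3 `COc1nc(N)nc2c1c(-c1ccco1)cn2[C@@H]1O[C@H](CO)[C@@H](O)[C@H]1O` gives > 20000 nM, a limit and not a number. Compound 1 `Nc1nc(N)c2c(-c3ccco3)cn([C@@H]3O[C@H](CO)[C@@H](O)[C@H]3O)c2n1` gives > 20000 nM, also a limit. Compound 2 `Cc1nc(N)c2c(-c3cc4ccccc4o3)cn([C@@H]3O[C@H](CO)[C@@H](O)[C@H]3O)c2n1` gives > 20000 nM, again a limit. Compound 3 therefore has no measured number, and neither of the other two values offers one for comparison. Among the measured compounds shown here, the whole series so far comes down to the limit of > 20000 nM in this assay, at which 3 of the 3 values shown sit.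

Compound 4 `COc1nc(N)nc2c1c(-c1ccsc1)cn2[C@@H]1O[C@H](CO)[C@@H](O)[C@H]1O` has thiophen-3-yl in place of furan-2-yl on an aromatic carbon.

For the measured compounds named here, no measured step covers a change at this place. Going by the values given here, the only step available, a step that the two limits leave unreadable from compound 1 to compound 3, concerns a different place and has no readable size to carry over. The expectation therefore rests on compound 3 at > 20000 nM, a limit, and on the absence of any measured number in the series. No step beyond the scatter is expected in either direction in this assay, and another limit is the most likely report. The estimated step is a number no higher from compound 3 to compound 4 (the limit leaves the size open). For compound 4 the estimate is 20000 nM, with an expected range from 6000 nM to 40000 nM.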

Compound 4, half-maximal inhibitory concentration: > 100000 nM
Compound 4: no number, only a limit; the forecaster's own chance of this, stated with the estimate: 75%; at least 5.0-fold (0.69 log units) between middle value and limit.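

In this assay compound 3 and compound 4 are both reported only as limits, and the step from the furan-2-yl group to the thiophen-3-yl group cannot be read. The compounds shown leave open what difference in inhibition, if any, separates thiophen-3-yl from furan-2-yl on the shared core.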